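The compounds below may be only part of what the source reports. "The series", "measured", "known", "first", "only" and "open" are said of these compounds alone.

In an assay on HEK293F cells for inhibition of cholesterol 24-hydroxylase (Homo sapiens), read by trypan blue exclusion, with stated times of 15 min and 5 h (on this read-out lower numbers stand for stronger inhibition and higher numbers for weaker inhibition), three compounds have been measured so far. Compound 1 `O=C(NC1CC1)C1CCN(c2cnccc2-c2ccccn2)CC1` gives 160 nM, compound 2 `O=C(NC1CC1)C1CCN(c2cncnc2-c2ccccc2)CC1` gives 44 nM, and compound 3 `CN(C)C(=O)C1CCN(c2cnccc2-c2ccccn2)CC1` gives 68 nM. On these numbers compound 3 stands second highest: its value and that of compound 2 lie within the scatter of each other, while compound 1 sits clearly higher. Among the measured compounds shown here, the one single-point step among the measured compounds is a 2.4-fold lower number from compound 1 to compound 3 (0.37 log units; beyond the scatter); it concerns the amide end of the molecule and not the aryl substituent.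

Compound 4 `Cc1cnn(-c2ccncc2N2CCC(C(=O)N(C)C)CC2)c1` differs from compound 3 by 4-methyl-1H-pyrazol-1-yl in place of pyridin-2-yl on an aromatic carbon. For the measured compounds named here, no measured pair isolates this kind of change. Going by the values given here, compounds 1 and 2 differ from each other in two places at once, and their values show only that compound 2 gives the lower number; they say nothing separable about the aryl group. The data therefore offer no direct guide for this step, and the expectation for compound 4 rests on compound 3 alone, with a correspondingly wide range. Compound 4 is expected to give 70 nM, with a range from 20 nM to 250 nM. The step this estimate implies, a 1.0-fold higher number from compound 3 to compound 4 (0.01 log units; within the scatter), is expected to stay within the scatter.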

Compound 4, half-maximal inhibitory concentration: 8.5 nM
Beside the measured number, compound 4's estimate is 8.2-fold (0.92 log units) above it; the whole stated range lies above it.
By their numbers in this assay, from the lowest: compound 4; then compounds 2 and 3 (each within the scatter of the next); then compound 1.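

Up to this point the only readable step lay at the amide end of the molecule, a 2.4-fold lower number from compound 1 to compound 3 (0.37 log units; beyond the scatter). In this assay, the step of an 8.0-fold lower number from compound 3 to compound 4 (0.90 log units; beyond the scatter) now shows that the aromatic carbon ortho to a large group and opposite the ring nitrogen also strongly affects the number, and that pyridin-2-yl is not needed there for a low value, since a five-membered aromatic ring with 2 hetero atoms takes the place of a six-membered aromatic ring with 1 hetero atom and the number falls beyond the scatter. Nothing shown here accounts for this drop.

On these data alone, this single step changes ring size, hetero atom count and the methyl group all at once, so it cannot assign the drop to any one of them, and how a 1H-pyrazol-1-yl without the methyl, or one bearing chlorine or trifluoromethyl in its place, would read remains open. As far as these compounds go, it also remains open whether the same exchange gives a step of similar size when cyclopropylamino stands on the carbonyl carbon, as in compound 1.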